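Swapping the imidazole for a primary amide

The compounds below may be only part of what the source reports. "The series", "measured", "known", "first", "only" and "open" are said of these compounds alone.

Compound 1 `CC(C)C(Cc1ncc[nH]1)c1ccc(-c2ccc3cccc(F)c3c2)[nH]c1=O` is the weakest-looking but not separable member of a small set. In a functional assay on CHO cells for antagonist activity at prostaglandin E2 receptor EP3 subtype (Homo sapiens), read by cAMP accumulation (on this read-out higher numbers stand for weaker inhibition and lower numbers for stronger inhibition), compound 1 gives 76 nM, the highest of the three numbers in hand. Its nearest neighbour is compound 3 `Cc1nc(C(c2ccc(-c3ccc4cccc(F)c4c3)[nH]c2=O)C(C)C)[nH]c1C`, which in this assay gives 50 nM. The furthest is compound 2 `CC(C)C(c1ccc(-c2ccc3cccc(F)c3c2)[nH]c1=O)N1CCN/C1=N\C#N`, which gives 38 nM. Both gaps lie within the scatter: a 1.5-fold lower number from compound 1 to compound 3 (0.18 log units; within the scatter) and a 2.0-fold lower number from compound 1 to compound 2 (0.30 log units; within the scatter). Compound 4 `CC(C)C(CC(N)=O)c1ccc(-c2ccc3cccc(F)c3c2)[nH]c1=O` is the next variant at the same position, with carbamoyl in place of 1H-imidazol-2-yl on a saturated chain carbon, two bonds along the chain from an aromatic carbon. Among the measured compounds shown here, the two measured steps that touch this carbon replaced one imidazole-bearing group by another ring-bearing group and moved the number only within the scatter; compound 4 instead gives up the ring altogether, for which no measured pair offers a direct guide. A modest weakening, a 2.0-fold higher number from compound 1 to compound 4 (0.30 log units; within the scatter), is therefore expected rather than a large one. Compound 4 is estimated at 150 nM, with a plausible range from 50 nM to 500 nM.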

Compound 4, half-maximal inhibitory concentration: 53 nM
Compound 4: the middle estimate sits 2.8-fold (0.45 log units) above what was measured; low and high end bracket the measured number.
By their numbers in this assay, from the lowest: compounds 2, 3, 4 and 1 (each within the scatter of the next).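

The ring on this chain carbon proves dispensable in this assay: with carbamoyl in place of 1H-imidazol-2-yl, the step is a 1.4-fold lower number from compound 1 to compound 4 (0.16 log units; within the scatter), so a group with no ring reads the same as the imidazole it replaces. The other two ring-bearing compounds give the same picture, with a 1.1-fold higher number from compound 3 to compound 4 (0.03 log units; within the scatter) and a 1.4-fold higher number from compound 2 to compound 4 (0.14 log units; within the scatter), so the four groups at this position cannot be told apart on this read-out. Nothing measured here accounts for why they read alike.

The compounds shown leave open how far this tolerance extends: a carboxylic acid, an amine or a plain methyl in place of carbamoyl might still separate from these four numbers. They also do not tell whether a longer chain carrying the carbamoyl, or a methyl on the amide nitrogen, would stay within the scatter.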